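The source may hold more compounds than are shown below. What is called first, only, known or untested is meant among the compounds shown, and "the series" means these compounds.

Compound 1 `O=C(Nc1cccc(-c2nc3ccccc3s2)c1)c1cc([N+](=O)[O-])ccc1Cl` is one of three measured compounds. In an ADME assay on HepG2 cells (Homo sapiens) for cytotoxicity, with a stated time of 72 h (on this read-out lower numbers stand for an effect already at smaller amounts and higher numbers for an effect only at larger amounts of compound), compound 1 gives > 27000 nM, which is a limit of the assay and not a number.
Compound 2 `O=C(Nc1ccc(Cl)c(-c2nc3ccccc3s2)c1)c1cc([N+](=O)[O-])ccc1Cl` follows. In this assay compound 2 gives > 25000 nM, again a limit.
Compound 3 `COc1ccc(NC(=O)c2cc([N+](=O)[O-])ccc2Cl)cc1-c1nc2ccccc2s1` completes the set. In this assay compound 3 gives > 25000 nM, also a limit.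

Compound 1 therefore stands only at a limit, and the two other values are limits as well. The three steps between the measured compounds, a step that the two limits leave unreadable from compound 1 to compound 2, a step that the two limits leave unreadable from compound 1 to compound 3 and a step that the two limits leave unreadable from compound 2 to compound 3, are all left unreadable by those limits. What can be said rests on the limit of > 25000 nM in this assay, at which 2 of the 3 values shown sit, and the limit of > 27000 nM in this assay, at which 1 of the 3 values shown sits: every compound in this set sits at the top of the measured range.

Compound 4 `O=C(Nc1cccc(-c2nc3ccccc3[nH]2)c1)c1cc([N+](=O)[O-])ccc1Cl` is not yet measured. It differs from compound 1 by 1H-benzimidazol-2-yl in place of 1,3-benzothiazol-2-yl on an aromatic carbon. Among the measured compounds shown here, none of the measured steps touches this part of the structure, and none has a readable size, so no direction or size beyond the scatter can be drawn from them. Given that compound 1 gives > 27000 nM and that all three measured values are limits, compound 4 is expected to stay at the limit too, with an at least 1.0-fold lower number from compound 1 to compound 4 (0.03 log units; that floor lies within the scatter) expected to lie within the scatter. The estimate for compound 4 is 25000 nM, within 8000 nM to 60000 nM.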

Compound 4, half-maximal effective concentration: > 27000 nM
Compound 4: a limit, no number; the forecaster's own chance of this, stated with the estimate: 65%; middle value at least 1.0-fold (0.03 log units) away from the limit.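

In this assay compound 4 gives > 27000 nM, which is a limit of the assay and not a number. Among the compounds shown here, compound 1 also stands only at a limit, so no step between compound 1 and compound 4 can be read. The four compounds leave open whether 1H-benzimidazol-2-yl in place of 1,3-benzothiazol-2-yl changes the read-out, and at what concentration any of them reaches a half-maximal effect.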